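A few compounds are considered here, and "the series" means these few. Any claim that something is new, unique, unknown or untested is made for them only; others in the source may bear on it.

Compound 2 `Cc1nn(-c2ccccc2C(C)C)c2c1[C@@H](c1ccc(Oc3ccccc3)cc1)S[C@@H](C)C(=O)N2` in an assay on isolated protein for agonist activity at Bile acid receptor (Homo sapiens), read by AlphaScreen, with a stated time of 30 min (a lower number here means that less compound is needed, a higher number that more compound is needed for the effect), gives 1900 nM, the second highest of three numbers, within the scatter of compound 3 `Cc1nn(-c2ccccc2C(F)(F)F)c2c1C(c1ccc(Oc3ccccc3)cc1)SC(C)C(=O)N2`, which gives 2000 nM, and within the scatter of compound 1 `Cc1ccccc1-n1nc(C)c2c1NC(=O)[C@H](C)S[C@@H]2c1ccc(Oc2ccccc2)cc1`, which gives 1300 nM. Compound 4 `CCc1ccccc1-n1nc(C)c2c1NC(=O)[C@H](C)S[C@@H]2c1ccc(Oc2ccccc2)cc1` differs from compound 2 by hydrogen in place of methyl on a saturated chain carbon bound to an aromatic carbon and a saturated chain carbon. For the measured compounds named here, the one step that bears on it is a 1.5-fold higher number from compound 1 to compound 2 (0.16 log units; within the scatter), which ran the other way along the same chain and stayed within the scatter. No step beyond the scatter is therefore expected for compound 4 in this assay. The expected step is a 1.2-fold lower number from compound 2 to compound 4 (0.07 log units; within the scatter). Compound 4 is estimated at 1600 nM, with a range from 800 nM to 3200 nM, pending the measurement.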

Compound 4, half-maximal effective concentration: 1100 nM
The estimate for compound 4 lay 1.5-fold (0.16 log units) above the measured number; measured number inside the range.
By their numbers in this assay, from the lowest: compounds 4, 1, 2 and 3 (each within the scatter of the next).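

In this assay, the change from 2-isopropylphenyl to 2-ethylphenyl gives a 1.7-fold lower number from compound 2 to compound 4 (0.24 log units; within the scatter), and adding one carbon to the methyl of compound 1 gives a 1.2-fold lower number from compound 1 to compound 4 (0.07 log units; within the scatter). Methyl, ethyl and isopropyl in this place are therefore not told apart in this assay, and the ethyl group adds a third member to that set, with both of its steps within the scatter. No supporting data bear on this result. Still open, going by these compounds, is whether a longer chain, an amine or a carboxylic acid in place of the isopropyl would take the number beyond the scatter.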